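Replacing 2,4-dichlorophenyl with 3,4-dihydroxyphenyl

The source may hold more compounds than are shown below. What is called first, only, known or untested is meant among the compounds shown, and "the series" means these compounds.

Measured in a functional assay on MCF7 cells (Homo sapiens) for cytotoxicity, read by MTT assay, with a stated time of 72 h; on this read-out lower numbers stand for stronger inhibition and higher numbers for weaker inhibition:
- Compound 1 `COc1cccc(/C=C2\CCC/C(=C\c3ccc(Cl)cc3)C2=O)c1OC`: 10300 nM
- Compound 2 `COc1cccc(/C=C2\CCC/C(=C\c3ccc(Cl)cc3Cl)C2=O)c1OC`: > 20000 nM

Compound 2 has no exact number and stands at the limit of > 20000 nM in this assay, at which 1 of the 2 values shown sits. Compound 3 `COc1cccc(/C=C2\CCC/C(=C\c3ccc(O)c(O)c3)C2=O)c1OC` has not yet been measured. It differs from compound 2 by one change: 3,4-dihydroxyphenyl in place of 2,4-dichlorophenyl on a double-bonded chain carbon bound to a double-bonded ring carbon. The change lies on a double-bonded chain carbon bound to a double-bonded ring carbon. Among the compounds with values here, only one measured step bears on it, the swap of chloro for hydrogen on that same aromatic ring, which gave an at least 1.9-fold higher number from compound 1 to compound 2 (0.28 log units; that floor lies within the scatter). Within the data shown here, no measured compound carries a 3,4-dihydroxyphenyl group, so that step gives only a weak guide to size. Compound 1 does give a number in this assay, at 10300 nM, so a modest move to a lower number is expected. The expected step is an at least 2.8-fold lower number from compound 2 to compound 3 (0.45 log units; beyond the scatter). For compound 3 the estimated value is 7000 nM, with an expected range of 2000 nM to 20000 nM.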

Compound 3, half-maximal inhibitory concentration: 4700 nM
Compound 3: middle estimate off by 1.5-fold (0.17 log units), on the high side; the measured number falls inside the stated range.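

In this assay, the place on a double-bonded chain carbon bound to a double-bonded ring carbon proves responsive to the group it carries, which the chloro step alone, lying within the scatter at its floor, could not show: 3,4-dihydroxyphenyl in place of 4-chlorophenyl gives a 2.2-fold lower number from compound 1 to compound 3 (0.34 log units; beyond the scatter). In place of 2,4-dichlorophenyl, the same group gives an at least 4.2-fold lower number from compound 2 to compound 3 (0.62 log units; beyond the scatter), and that size is only a floor. Compound 2 has a limit and not a number: the limit of > 20000 nM in this assay, at which 1 of the 3 values shown sits.

The compounds shown leave open whether an unsubstituted phenyl group would match compound 3, which would separate gaining the hydroxyl groups from losing chlorine. Going by these compounds, it also remains open whether a phenyl group with a single hydroxyl, or with an amine, would serve as well.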